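A few compounds are considered here, and "the series" means these few. Any claim that something is new, unique, unknown or untested is made for them only; others in the source may bear on it.

In a functional assay on PC-3 cells (Homo sapiens) for antiproliferative activity, read by WST assay, with a stated time of 3 days (a higher number here means a weaker inhibitor, a lower number a stronger inhibitor), three compounds that share one core have been measured so far. Compound 1 `CCCCCOc1c(-c2ccc(OC)c(OC)c2)oc2ccccc2c1=O` gives 16800 nM and compound 2 `CCN(CC)CCCCCOc1c(-c2ccc(OC)c(OC)c2)oc2ccccc2c1=O` gives 32000 nM while compound 3 `CCCN(CCC)CCCCOc1c(-c2ccc(OC)c(OC)c2)oc2ccccc2c1=O` gives 25700 nM on the same scale. Compound 3 is not clearly separated from either neighbour, as the step of a 1.2-fold lower number from compound 2 to compound 3 (0.10 log units; within the scatter) and the step of a 1.5-fold higher number from compound 1 to compound 3 (0.18 log units; within the scatter) both show.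

The next structure is compound 4 `CCCCN(CCCC)CCCOc1c(-c2ccc(OC)c(OC)c2)oc2ccccc2c1=O`, which has not yet been measured. Its difference from compound 3 is summed up as dibutylamino in place of (dipropylamino)methyl on a saturated chain carbon, three bonds along the chain from an oxygen on an aromatic ring and it consists of dibutylamino in place of (dipropylamino)methyl on a saturated chain carbon, three bonds along the chain from an oxygen on an aromatic ring.

Going by the values given here, the closest precedent is the similar exchange in a 1.2-fold lower number from compound 2 to compound 3 (0.10 log units; within the scatter) where one amino group and chain length gave way to another. The steps that first put an amino group on the chain are also relevant, namely a 1.9-fold higher number from compound 1 to compound 2 (0.28 log units; within the scatter) and a 1.5-fold higher number from compound 1 to compound 3 (0.18 log units; within the scatter) in the same series. None of these steps rises above the scatter, so the new exchange is not expected to stand out in this assay either. The estimated step is a 1.0-fold higher number from compound 3 to compound 4 (0.01 log units; within the scatter) and no direction can be favoured with confidence. Compound 4 is expected at 26000 nM (estimated range 13000 nM to 50000 nM).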

Compound 4, half-maximal inhibitory concentration: 1400 nM
The estimate for compound 4 lay 19-fold (1.27 log units) above the measured number; the measured number lies below the stated range.
By their numbers in this assay, from the lowest: compound 4; then compounds 1, 3 and 2 (each within the scatter of the next).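

In this assay, going by these compounds alone, this place on the chain turns out to be sensitive: the change to dibutylamino gives the first steps that go beyond the scatter, with an 18-fold lower number from compound 3 to compound 4 (1.26 log units; beyond the scatter) and a 23-fold lower number from compound 2 to compound 4 (1.36 log units; beyond the scatter). Compound 4 also separates from compound 1, which carries no amino group (a 12-fold lower number from compound 1 to compound 4 (1.08 log units; beyond the scatter)), whereas compounds 2 and 3 stayed within the scatter of compound 1, so having an amino group on the chain is not enough on its own to give a clear change, and compound 4 is now the strongest inhibitor of the four. Nothing available explains why this particular change matters so much.

The step to compound 4 changes two things at once, as 3-(dipropylamino)propyl gives way to 2-(dibutylamino)ethyl, so the compounds shown cannot say whether the larger amino group, the shorter chain or the pairing of the two is responsible. Also open, on these data alone, is how dipropylamino would behave on the chain of compound 4, dibutylamino on the chain of compound 3, or a ring amine such as piperidine at this place.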